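Chloro in Place of Hydrogen on the Aryl Ether

This account rests on a few compounds, and the source may have more. Where it says the series, first, only, none or still open, it means among the compounds named here.

Measured compounds:
Compound 1 `O=C1NC(=O)C(Cc2ccc(Oc3ccc(Cl)cn3)cc2)S1` in a functional assay for agonist activity at Free fatty acid receptor 1 (Homo sapiens), read by FLIPR, in the presence of a further agent that is not named here (on this read-out higher numbers stand for an effect only at larger amounts of compound and lower numbers for an effect already at smaller amounts), gives 1870 nM.
Compound 2 `Cc1ccc(Oc2ccc(CC3SC(=O)NC3=O)cc2)cc1` in this assay gives 547 nM.
Compound 3 `O=C1NC(=O)C(Cc2ccc(Oc3ccccc3)cc2)S1` in this assay gives 307 nM.

Compound 3 stands at the lowest of the three numbers. Its nearest neighbour is compound 2, separated by a 1.8-fold lower number from compound 2 to compound 3 (0.25 log units; within the scatter), a gap that lies within the scatter, so no order between these two can be claimed. Compound 1 sits furthest away, with a 6.1-fold lower number from compound 1 to compound 3 (0.78 log units; beyond the scatter), and likewise a 3.4-fold lower number from compound 1 to compound 2 (0.53 log units; beyond the scatter) separates compound 1 from compound 2.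

Compound 4 `O=C1NC(=O)C(Cc2ccc(Oc3cccc(Cl)c3)cc2)S1` is not yet measured. It differs from compound 3 by chloro in place of hydrogen on an aromatic carbon. Within the data shown here, no measured step places a chloro on the phenyl ring itself, so the bearing steps are indirect: the step from compound 2 to compound 3 shows that a methyl on this ring changes little, while the step from compound 1 to compound 3 shows that replacing the whole phenyl by a chloropyridinyl group costs a modest amount. A small chloro addition is therefore expected to move this assay by at most a modest step, in either direction, most likely within the scatter. Compound 4 is estimated at 400 nM, with a range from 150 nM to 1100 nM, which means an expected step of a 1.3-fold higher number from compound 3 to compound 4 (0.11 log units; within the scatter).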

Compound 4, half-maximal effective concentration: 318 nM
For compound 4 the middle estimate is 1.3-fold (0.10 log units) above the measured one; low and high end bracket the measured number.
By their numbers in this assay, from the lowest: compounds 3, 4 and 2 (each within the scatter of the next); then compound 1.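

In this assay, among these compounds, chloro in place of hydrogen on an aromatic carbon of the phenyl ring, meta to a large group, gives a step that cannot be read as a change (a 1.0-fold higher number from compound 3 to compound 4 (0.02 log units; within the scatter)), and this is the first direct view of a substituent at this place on that ring. The 3-chlorophenyl group also cannot be told apart from the 4-methylphenyl group (a 1.7-fold lower number from compound 2 to compound 4 (0.24 log units; within the scatter)), yet it stays clear of the 5-chloropyridin-2-yl group (a 5.9-fold lower number from compound 1 to compound 4 (0.77 log units; beyond the scatter)), so among these compounds a chloro on the aryl ring does not by itself go with the higher number of compound 1. Nothing shown here offers an explanation for either result.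

Going by these compounds, it remains open whether a methoxy, an amine or a carboxylic acid at this same place would also leave the number within the scatter, or whether chloro on another carbon of the ring would do so. Also open, on these data alone, is whether an unsubstituted pyridin-2-yl group would stand with compound 1 or with compound 3, which would show which part of the 5-chloropyridin-2-yl group goes with its step.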